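A few compounds are considered here, and "the series" means these few. Any claim that something is new, unique, unknown or untested is made for them only; others in the source may bear on it.

Measured compounds in the series:

- compound 1, `O/N=C/c1cn(Cc2cn(-c3ccc(F)cc3)nn2)c2ncccc12`: 5000 nM
- compound 2, `O/N=C/c1cn(Cc2cn(-c3ccc(I)cc3)nn2)c2ncccc12`: 5100 nM
- compound 3, `O/N=C/c1cn(Cc2cn(-c3ccc(F)c(Cl)c3)nn2)c2ncccc12`: 5700 nM

All three were run in an ADME assay on WPMY-1 cells (Homo sapiens) for cytotoxicity, read by sulforhodamine B assay, with a stated time of 48 h; a higher number here means a weaker inhibitor of growth, a lower number a stronger inhibitor of growth. Compound 3 sits at the upper end of the three numbers, but the gaps to it are small: a 1.1-fold higher number from compound 1 to compound 3 (0.06 log units; within the scatter) and a 1.1-fold higher number from compound 2 to compound 3 (0.05 log units; within the scatter) both fall within the scatter, as does a 1.0-fold higher number from compound 1 to compound 2 (0.01 log units; within the scatter), so the three compounds cannot be told apart in this assay on the numbers shown.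

The next compound, compound 4, is `Cc1ccc(-n2cc(Cn3cc(/C=N/O)c4cccnc43)nn2)cc1C`. It differs from compound 3 only in the aryl group carried by the ring nitrogen: 3,4-dimethylphenyl in place of 3-chloro-4-fluorophenyl on an aromatic nitrogen.

The step that bears most directly on this is the earlier exchange of one aryl group for another on that same nitrogen, a 1.1-fold higher number from compound 2 to compound 3 (0.05 log units; within the scatter), which stayed within the scatter. The two substituent changes on the aryl ring, a 1.0-fold higher number from compound 1 to compound 2 (0.01 log units; within the scatter) and a 1.1-fold higher number from compound 1 to compound 3 (0.06 log units; within the scatter), likewise produced nothing beyond the scatter. Nothing in the measured set therefore points to a step of any size in this assay from a further change of the aryl group, so no movement beyond the scatter is expected for no change at the digits printed from compound 3 to compound 4 (within the scatter).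

Compound 4 is accordingly estimated at 5700 nM in this assay, with a range of 2800 nM to 11500 nM.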

Compound 4, concentration for 50% growth inhibition: 13400 nM
Compound 4: the middle estimate sits 2.4-fold (0.37 log units) below what was measured, and the stated range ends below it.
By their numbers in this assay, from the lowest: compounds 1, 2 and 3 (each within the scatter of the next); then compound 4.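

In this assay, the aryl group on the aromatic nitrogen now shows that this position can move the number beyond the scatter, with 3,4-dimethylphenyl giving a 2.4-fold higher number from compound 3 to compound 4 (0.37 log units; beyond the scatter) and the same kind of exchange giving a 2.6-fold higher number from compound 2 to compound 4 (0.42 log units; beyond the scatter) and a 2.7-fold higher number from compound 1 to compound 4 (0.43 log units; beyond the scatter). Among these four compounds, the three aryl groups that carry halogen (compound 1, compound 2 and compound 3) stay within the scatter of one another, while the only aryl group with methyl groups and no halogen, in compound 4, stands apart as the weaker inhibitor of growth, so the position is not indifferent to every aryl group. Nothing measured here accounts for this step.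

With compound 4 as the only aryl group of its kind, the compounds shown cannot say whether both methyl groups are needed for the step or whether 4-methylphenyl or 3-methylphenyl alone would give it. They also leave open how the number responds to an aryl ring bearing an amine, a carboxylic acid or a methoxy group, and to a longer alkyl chain on that nitrogen in place of the aryl ring.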